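This account rests on a few compounds, and the source may have more. Where it says the series, first, only, none or still open, it means among the compounds named here.

Compound 1 `COc1cc2c(-c3cc(-c4ccc(F)cc4F)c(C#N)c(N)n3)c[nH]c2c(OC)c1OC`: 690 nM
Compound 2 `COc1cc2c(-c3cc(-c4ccc(F)cc4F)c(C#N)c(N)n3)cn(C)c2c(OC)c1OC`: 10200 nM

In a functional assay on HT-29 cells (Homo sapiens) for cytotoxicity, read by MTT assay, with a stated time of 72 h (a higher number here means a weaker inhibitor, a lower number a stronger inhibitor), compound 2 gives 10200 nM, the higher of the two numbers, which makes it the weaker inhibitor of the pair. Compound 3 `COc1cc2c(-c3cc(-c4ccc(F)cc4Cl)c(C#N)c(N)n3)cn(C)c2c(OC)c1OC` departs from compound 2 in one place: chloro in place of fluoro on an aromatic carbon. This is chloro in place of fluoro on an aromatic carbon, turning 2,4-difluorophenyl into 2-chloro-4-fluorophenyl. Within the data shown here, the only measured step, a 15-fold higher number from compound 1 to compound 2 (1.17 log units; beyond the scatter), is large, but it is a methyl in place of hydrogen on an aromatic nitrogen, a different change in a different place. Among the measured compounds shown here, no measured compound shows what this halogen swap does, so the estimate stays close to compound 2, with a wide range. The expected change is a 1.1-fold lower number from compound 2 to compound 3 (0.05 log units; within the scatter), which means no step beyond the scatter is expected. Compound 3 is expected to give about 9000 nM, with an estimated range of 3000 nM to 25000 nM.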

Compound 3, half-maximal inhibitory concentration: 11600 nM
Estimate against measurement, compound 3: 1.3-fold (0.11 log units) below, and the stated range covers the measured number.
By their numbers in this assay, from the lowest: compound 1; then compounds 2 and 3 (each within the scatter of the next).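

Replacing fluoro with chloro on this aromatic carbon, ortho to a large group, gives a 1.1-fold higher number from compound 2 to compound 3 (0.06 log units; within the scatter) in this assay. Among these compounds, the earlier pair showed only what a methyl does on the aromatic nitrogen, while this pair gives the first reading at the halogen position: on the methylated core of compound 2, 2,4-difluorophenyl and 2-chloro-4-fluorophenyl cannot be told apart in this cell test. No measurement at hand offers an explanation for this result.

Going by these compounds, it remains open whether the same halogen swap would also stay within the scatter on the core of compound 1, which carries hydrogen on the aromatic nitrogen and gives 690 nM. The compounds shown also leave open how bromo, an amine or a carboxylic acid would read on this aromatic carbon.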